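The compounds below may be only part of what the source reports. "The series", "measured", "known", "first", "only" and "open" are said of these compounds alone.

Compound 1 `CC1OC(OC2CCCCC2OCCCCC(C(=O)O)C(=O)O)C(O)C(O)C1O` and compound 2 `CC1OC(OC2CCCCC2OCCCCCC(C(=O)O)C(=O)O)C(O)C(O)C1O` share one core; compound 2 differs by 2,2-dicarboxyethyl in place of dicarboxymethyl on a saturated chain carbon, four bonds along the chain from an oxygen on a saturated carbon. In a functional assay on HL-60 cells (Homo sapiens) for inhibition (a higher number here means a weaker inhibitor, a lower number a stronger inhibitor), compound 1 reaches only a limit of the assay, > 5000000 nM. Compound 2 likewise gives only a limit, > 5000000 nM. The step that the two limits leave unreadable from compound 1 to compound 2 cannot be sized because both values sit at the limit of > 5000000 nM in this assay, at which 2 of the 3 values shown sit, in this assay.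

Compound 3 `CC1OC(OC2CCCCC2OC(=O)NCCC(C(=O)O)C(=O)O)C(O)C(O)C1O` has another core; how its core differs from that of compound 1 is not broken down here. In this assay, for the measured compounds named here, compound 3 gives 3500000 nM, the only plain number among the three. Compound 4 `CC1OC(OC2CCCCC2OC(=O)NCCCC(C(=O)O)C(=O)O)C(O)C(O)C1O` is not yet measured and carries the same kind of change, (2,2-dicarboxyethyl in place of dicarboxymethyl on a saturated chain carbon, two bonds along the chain from an amide-type nitrogen), though the place differs: two bonds along the chain from an amide-type nitrogen rather than four bonds along the chain from an oxygen on a saturated carbon. Only a small step is expected, a 1.3-fold higher number from compound 3 to compound 4 (0.11 log units; within the scatter), resting on the unreadable step that the two limits leave unreadable from compound 1 to compound 2. Compound 4 is thus estimated at 4500000 nM, expected between 2000000 nM and 10000000 nM.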

Compound 4, half-maximal inhibitory concentration: 700000 nM
Beside the measured number, compound 4's estimate is 6.4-fold (0.81 log units) above it; measured number outside the range, below it.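

In this assay, putting 2,2-dicarboxyethyl in place of dicarboxymethyl on the core of compound 3 gives a 5.0-fold lower number from compound 3 to compound 4 (0.70 log units; beyond the scatter), so the change has a readable effect on this core. On the core of compound 1, the same change cannot be read, because compound 1 and compound 2 both stop at a limit of the assay: the limit of > 5000000 nM in this assay, at which 2 of the 4 values shown sit. The series therefore holds one readable step, which does not show whether the change carries from one core to another.

From the compounds shown here alone, whether a still longer chain on the core of compound 3 would lower the number further remains open. So does the effect of a single carboxylic acid in place of the pair.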